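Chain Lengthening in an Acyl-CoA:Cholesterol Acyltransferase Series

The source may report more compounds than this note shows. Statements on the series, on what has been measured and on what is new or still open speak of the compounds shown alone.

Measured compounds:
compound 1, `CCCCCCCC/C=C/CCCCCCCC(=O)Nc1ccccc1CC`: 1200 nM
compound 2, `CCCCCCCC/C=C/CCCCCCCC(=O)Nc1ccccc1C(C)C`: 600 nM
compound 3, `CCCCCCCCCCCCCC(=O)Nc1c(OC)cc(OC)cc1OC`: 190 nM

In an assay on microsomes from intestine for inhibition of acyl-CoA:cholesterol acyltransferase (Oryctolagus cuniculus) (a lower number here means a stronger inhibitor, a higher number a weaker inhibitor), compound 3 gives the lowest number, 190 nM, and its steps to compound 1 and compound 2 lie beyond the scatter, so it is the most potent of the three. The difference between the core of compound 3 and the core of compound 1 is not broken down here. Compound 2 arises from compound 1 by methyl in place of hydrogen on a saturated chain carbon bound to an aromatic carbon and a saturated chain carbon, and the step is a 2.0-fold lower number from compound 1 to compound 2 (0.30 log units; within the scatter).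

Compound 4, `CCCCCCCCCCCCCCC(=O)Nc1c(OC)cc(OC)cc1OC`, is not yet measured in this assay. It arises from compound 3 by methyl in place of hydrogen on a saturated chain carbon, ten or more bonds along the chain from a carbonyl carbon. This is the same kind of change as from compound 1 to compound 2, though the place differs: there the carbon is bound to an aromatic carbon, here it lies within the saturated chain. Because a 2.0-fold lower number from compound 1 to compound 2 (0.30 log units; within the scatter) stayed within the scatter, the step for compound 4 is expected to be small, a 1.1-fold lower number from compound 3 to compound 4 (0.05 log units; within the scatter). Compound 4 is thus estimated at 170 nM, between 85 nM and 350 nM.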

Compound 4, half-maximal inhibitory concentration: 65 nM
For compound 4 the middle estimate is 2.6-fold (0.42 log units) above the measured one; measured number below the stated range.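

In this assay, methyl in place of hydrogen on the saturated chain gives a 2.9-fold lower number from compound 3 to compound 4 (0.47 log units; beyond the scatter). Set beside the same change on the other core, this step cannot be told apart from the earlier one: the same change on two cores in this assay, a 2.0-fold lower number (0.30 log units; within the scatter) from compound 1 to compound 2 and a 2.9-fold lower number (0.47 log units; beyond the scatter) from compound 3 to compound 4, 1.5-fold (0.16 log units) apart, within the scatter of two such steps. The change thus carries across these two cores without a measurable difference in size, even though its place differs, but with a single pair on each core this does not show that the step would hold on other cores or that a smaller real difference is absent.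

The compounds shown leave open whether a longer chain on the core of compound 3 would lower the number further. They also leave open what a carboxylic acid in place of the added methyl would do.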